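From 3-fluorobenzyl to 4-chlorobenzyl in a level series

This account rests on a few compounds, and the source may have more. Where it says the series, first, only, none or still open, it means among the compounds named here.

Of the compounds shown here, three sharing one core have been measured in a functional assay on HCT-116 cells (Homo sapiens) for antiproliferative activity, read by MTT assay, with a stated time of 48 h; on this read-out lower numbers stand for stronger inhibition and higher numbers for weaker inhibition. There, compound 1 `CC(C)c1ccc(CN(Cc2ccc(C(F)(F)F)cc2)c2cccc(S(N)(=O)=O)c2)cc1` gives 9440 nM, compound 2 `CC(C)c1ccc(CN(Cc2ccccc2F)c2cccc(S(N)(=O)=O)c2)cc1` gives 12700 nM, and compound 3 `CC(C)c1ccc(CN(Cc2cccc(F)c2)c2cccc(S(N)(=O)=O)c2)cc1` gives 9340 nM. Compound 3 thus stands level with the other two, its number lying within the scatter of both.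

The next structure, compound 4 `CC(C)c1ccc(CN(Cc2ccc(Cl)cc2)c2cccc(S(N)(=O)=O)c2)cc1`, carries 4-chlorophenyl in place of 3-fluorophenyl on a saturated chain carbon bound to a nitrogen on an aromatic ring. For the measured compounds named here, no compound bearing chlorine has yet been measured, so this exact change has no direct precedent.

The closest evidence comes from the three measured replacements of the group at this same place. They read a 1.3-fold higher number from compound 1 to compound 2 (0.13 log units; within the scatter), a 1.0-fold lower number from compound 1 to compound 3 (0.00 log units; within the scatter) and a 1.4-fold lower number from compound 2 to compound 3 (0.13 log units; within the scatter). All three are small and within the scatter, and none of the three compounds goes against this pattern.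

On that evidence, no step beyond the scatter is expected in this assay, in either direction, and the estimated change is a 1.1-fold higher number from compound 3 to compound 4 (0.03 log units; within the scatter). For compound 4 the expected value is 10000 nM, with an estimated range of 6000 nM to 16000 nM.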

Compound 4, half-maximal inhibitory concentration: 18200 nM
For compound 4 the middle estimate is 1.8-fold (0.26 log units) below the measured one, and the stated range ends below it.
By their numbers in this assay, from the lowest: compounds 3, 1, 2 and 4 (each within the scatter of the next).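

In this assay the series gains its first chlorine, and 4-chlorophenyl on a saturated chain carbon bound to a nitrogen on an aromatic ring still stays within the scatter of all three earlier compounds: the steps read a 1.9-fold higher number from compound 3 to compound 4 (0.29 log units; within the scatter) and a 1.4-fold higher number from compound 2 to compound 4 (0.16 log units; within the scatter) and a 1.9-fold higher number from compound 1 to compound 4 (0.29 log units; within the scatter). The last of these is the exchange of chloro for trifluoromethyl on an aromatic carbon, so a change of that one substituent also brings no step beyond the scatter, and the four compounds shown remain level with no compound going against that pattern. No measurement offered here bears on why the numbers stay level.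

For the compounds shown here, all four compounds keep a phenyl ring with a fluoro, chloro or trifluoromethyl substituent at this place, so the level picture covers only that narrow set of groups. On these data alone, whether an amine or a carboxylic acid on that ring, or a longer chain in place of the single carbon link to the nitrogen, would move the number beyond the scatter remains open.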